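This account rests on a few compounds, and the source may have more. Where it says the series, first, only, none or still open, it means among the compounds named here.

Compound 1 `O=C(N/N=C/c1c(-c2cc3ccccc3oc2=O)[nH]c2ccccc12)c1ccc(Cl)cc1` gives in a functional assay on MCF7 cells (Homo sapiens) for inhibition, read by MTT assay, with a stated time of 48 h (on this read-out lower numbers stand for stronger inhibition and higher numbers for weaker inhibition), only a limit, > 200000 nM.
Compound 2 `O=C(N/N=C/c1c(-c2cc3ccc(Br)cc3oc2=O)[nH]c2ccccc12)c1ccc(Cl)cc1` gives 13800 nM.

Compound 2 thus holds the only number shown; the other value is a limit. Compound 3 `O=C(N/N=C/c1c(-c2cc3ccc(Br)cc3oc2=O)[nH]c2ccccc12)c1ccc(Cl)cc1F` differs from compound 2 by one change: fluoro in place of hydrogen on an aromatic carbon. Going by the values given here, the single measured step, an at least 14-fold lower number from compound 1 to compound 2 (1.16 log units; beyond the scatter), concerns a bromo group on another ring of the shared core and offers little guidance for adding fluoro here. The step from compound 2 to compound 3 is therefore expected to stay within the scatter: a 1.2-fold lower number from compound 2 to compound 3 (0.06 log units; within the scatter). Compound 3 is estimated at 12000 nM, with a range from 4000 nM to 40000 nM.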

Compound 3, half-maximal inhibitory concentration: > 200000 nM
Compound 3: only a limit was reported (the forecaster's own chance of this, stated with the estimate: 5%); at least 16-fold (1.22 log units) between middle value and limit.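

In this assay, adding fluoro to the 4-chlorophenyl ring gives an at least 14-fold higher number from compound 2 to compound 3 (1.16 log units; beyond the scatter). This is the first change shown on this ring, and it reveals that the position is sensitive: a single added atom, ortho to a large group and meta to the chloro group, is enough to lose the measurable value. Compound 3 gives only a limit, so its true value stays unknown: the limit of > 200000 nM in this assay, at which 2 of the 3 values shown sit.

As far as these compounds go, whether this loss is specific to fluoro or would follow any group at this position remains open. An amine or a methyl group in the same place could tell these two readings apart.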